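Aromatic fluoro substitution: from compound 2 to compound 4

The compounds below may be only part of what the source reports. "The series", "measured", "known", "first", "only" and "open" are said of these compounds alone.

Compound 1 `Cc1ccc2oc(/C=C/[S+](C)[O-])cc(=O)c2c1`: 7000 nM
Compound 2 `C[S+]([O-])/C=C/c1cc(=O)c2ccccc2o1`: 8000 nM
Compound 3 `Cc1c(/C=C/[S+](C)[O-])oc2ccccc2c1=O`: 7200 nM

In a functional assay on DLD-1 cells (Homo sapiens) for cytotoxicity, with a stated time of 48 h (on this read-out lower numbers stand for stronger inhibition and higher numbers for weaker inhibition), compound 2 gives 8000 nM, the upper end of the three numbers shown, yet both neighbours sit within the scatter: a 1.1-fold higher number from compound 1 to compound 2 (0.06 log units; within the scatter) and a 1.1-fold lower number from compound 2 to compound 3 (0.05 log units; within the scatter). No ordering among compounds 1, 2 and 3 can be claimed. Compound 4 `C[S+]([O-])/C=C/c1cc(=O)c2cc(F)ccc2o1` is not yet measured; it differs from compound 2 as follows: fluoro in place of hydrogen on an aromatic carbon. The two measured steps both swap methyl and hydrogen on an aromatic carbon and are flat; neither involves fluoro, so they bear only loosely on this change. Because compound 2 gives 8000 nM and the known steps are flat, the expected step is no change at the digits printed from compound 2 to compound 4 (within the scatter), with no shift beyond the scatter anticipated. Compound 4 is estimated at 8000 nM, range 4500 nM to 14000 nM.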

Compound 4, half-maximal inhibitory concentration: 7000 nM
For compound 4 the middle estimate is 1.1-fold (0.06 log units) above the measured one; low and high end bracket the measured number.
By their numbers in this assay, from the lowest: compounds 1, 4, 3 and 2 (each within the scatter of the next).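

In this assay, fluoro on this aromatic carbon, meta to a fused ring and para to a fused ring, stays within the scatter of hydrogen (a 1.1-fold lower number from compound 2 to compound 4 (0.06 log units; within the scatter)) and of methyl (no change at the digits printed from compound 1 to compound 4 (within the scatter)). Hydrogen, methyl and fluoro at this place therefore cannot be ordered, and the flat result now extends to a halogen. Nothing measured here explains this flatness.

Going by these compounds, whether an amine, a carboxylic acid or a longer chain at this carbon would give a step beyond the scatter remains open. Also open, on these data alone, is how fluoro behaves on the other aromatic carbons of the shared core.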